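A few compounds are considered here, and "the series" means these few. Any claim that something is new, unique, unknown or untested is made for them only; others in the source may bear on it.

Working notes on the series built on the core of compound 1 `CC1(C)OC(=O)C2(C(=O)O1)[C@@H](c1ccco1)CC(=O)C[C@H]2c1ccc(Br)cc1`. In an ADME assay on MT2 cells (Homo sapiens) for cytotoxicity (on this read-out lower numbers stand for higher toxicity in this test and higher numbers for lower toxicity in this test), compound 1 gives only a limit, > 111000 nM. Compound 2 `COc1ccc([C@@H]2CC(=O)C[C@H](c3ccco3)C23C(=O)OC(C)(C)OC3=O)c(C)c1` likewise gives only a limit in this assay, > 111000 nM. Among the compounds with values here, the step that the two limits leave unreadable from compound 1 to compound 2 is therefore not readable; the only evidence is the limit of > 111000 nM in this assay, at which 2 of the 2 values shown sit. Compound 3 `COc1cccc([C@@H]2CC(=O)C[C@H](c3ccco3)C23C(=O)OC(C)(C)OC3=O)c1OC` carries 2,3-dimethoxyphenyl in place of 4-methoxy-2-methylphenyl on a saturated ring carbon. Within the data shown here, only that one unreadable step bears on the change, so no direction can be drawn and no step beyond the scatter is expected. Compound 3 is expected to stay at the limit, estimated at 111000 nM within 50000 nM to 300000 nM. The expected step is a number no higher from compound 2 to compound 3 (the limit leaves the size open).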

Compound 3, half-maximal cytotoxic concentration: > 111000 nM
Compound 3: a limit, no number; the forecaster's own chance of this, stated with the estimate: 85%; the middle value sits exactly at the limit.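

Within the data shown here, compound 3 also gives only a limit in this assay, so no step among compound 1, compound 2 and compound 3 can be read: the limit of > 111000 nM in this assay, at which 3 of the 3 values shown sit. Where the cytotoxic concentration of any of these compounds lies, and whether these changes of group shift it, stays open.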